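The source may hold more compounds than are shown below. What is called first, only, known or untested is meant among the compounds shown, and "the series" means these compounds.

Working notes on the series. Compound 1 `COc1cc(C(F)(F)F)cc(C(F)(F)F)c1C(=O)NC1(c2ccccc2)CCCN(Cc2ccccc2)C1` carries a benzyl group on the amine nitrogen in the ring; in an assay on cells for inhibition of sodium- and chloride-dependent glycine transporter 1 (Homo sapiens) (a lower number here means that less compound is needed, a higher number that more compound is needed for the effect), compound 1 gives 6700 nM. Compound 2 `COc1cc(C(F)(F)F)cc(C(F)(F)F)c1C(=O)NC1(c2ccccc2)CCCN(C(C)=O)C1` has acetyl in place of benzyl there. In this assay compound 2 gives > 10000 nM, which is a limit of the assay and not a number (the limit of > 10000 nM in this assay, at which 1 of the 3 values shown sits). The step of an at least 1.4-fold higher number from compound 1 to compound 2 (0.17 log units; that floor lies within the scatter) is thus only a floor. Compound 3 `COc1cc(C(F)(F)F)cc(SC)c1C(=O)NC1(c2ccc(Cl)cc2)CCCN(C)C1` gives 28 nM in this assay, the lowest of the two numbers seen, well separated from compound 1. Compound 4 `COc1cc(C(F)(F)F)cc(SC)c1C(=O)NC1(c2ccncn2)CCCN(C)C1` differs from compound 3 by pyrimidin-4-yl in place of 4-chlorophenyl on a saturated ring carbon. For the measured compounds named here, no measured step touches the group on the saturated ring carbon; the single known step sits on the amine nitrogen, so it does not bear on this change. A moderate rise is expected, a 7.1-fold higher number from compound 3 to compound 4 (0.85 log units; beyond the scatter). Compound 4 is therefore estimated at 200 nM, within 40 nM to 1500 nM.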

Compound 4, half-maximal effective concentration: 1700 nM
For compound 4 the middle estimate is 8.5-fold (0.93 log units) below the measured one, outside the stated range (above it).
By their numbers in this assay, from the lowest: compound 3; then compound 4; then compound 1. At a limit, above all of these: compound 2.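

In this assay, for the compounds shown here, pyrimidin-4-yl in place of 4-chlorophenyl gives a 61-fold higher number from compound 3 to compound 4 (1.78 log units; beyond the scatter) and so shows for the first time that the group on the saturated ring carbon strongly affects the number. The step removes the chlorine and brings in two ring nitrogens together, and this single pair cannot separate those contributions. Nothing measured here bears on the cause of this step. On these data alone, whether a pyridin-2-yl or 4-methoxyphenyl group on this carbon would lie nearer compound 3 or compound 4 remains open. Also open, as far as these compounds go, is whether a step of this size would recur on the core of compound 1.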